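This account rests on a few compounds, and the source may have more. Where it says the series, first, only, none or still open, it means among the compounds named here.

Of the compounds shown here, three sharing one core have been measured in a functional assay on NCI-H460 cells (Homo sapiens) for cytotoxicity, read by MTT assay, with a stated time of 3 days; on this read-out higher numbers stand for weaker inhibition and lower numbers for stronger inhibition. Compound 1 `N#Cc1c(O)nc(SCc2nc3ccccc3[nH]2)nc1-c1ccccc1`, with hydroxy on an aromatic carbon, gives 2.5 nM. Compound 2 `CNc1nc(SCc2nc3ccccc3[nH]2)nc(-c2ccccc2)c1C#N`, with methylamino there, gives 3.2 nM. Compound 3 `N#Cc1c(Nc2nccs2)nc(SCc2nc3ccccc3[nH]2)nc1-c1ccccc1`, with (1,3-thiazol-2-yl)amino, gives 3.37 nM. Compound 3 thus stands within the scatter of both others, nearest to compound 2 and furthest from compound 1.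

Compound 4 `CN1CCN(c2nc(SCc3nc4ccccc4[nH]3)nc(-c3ccccc3)c2C#N)CC1` changes the group at that same place, ortho to a cyano group: 4-methylpiperazin-1-yl in place of (1,3-thiazol-2-yl)amino on an aromatic carbon. All three measured steps concern the group at this place: a 1.3-fold higher number from compound 1 to compound 2 (0.11 log units; within the scatter), a 1.3-fold higher number from compound 1 to compound 3 (0.13 log units; within the scatter) and a 1.1-fold higher number from compound 2 to compound 3 (0.02 log units; within the scatter). Each lies within the scatter, although the groups exchanged differ widely. Among the measured compounds shown here, none of the measured compounds carries a non-aromatic ring here, however, so these steps are only indirect guidance and the range has to stay wide. With compound 3 separated from compound 2 by only a 1.1-fold higher number from compound 2 to compound 3 (0.02 log units; within the scatter), no step beyond the scatter is expected in this assay. The expected change is a 1.2-fold higher number from compound 3 to compound 4 (0.07 log units; within the scatter). Compound 4 is estimated at 4 nM, with an expected range from 1.5 nM to 12 nM.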

Compound 4, half-maximal inhibitory concentration: 2.84 nM
Compound 4: middle estimate off by 1.4-fold (0.15 log units), on the high side; low and high end bracket the measured number.
By their numbers in this assay, from the lowest: compounds 1, 4, 2 and 3 (each within the scatter of the next).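

In this assay, among the compounds shown here, compound 4 brings a non-aromatic ring to this place for the first time, and its 4-methylpiperazin-1-yl group stays within the scatter of every group seen there: a 1.2-fold lower number from compound 3 to compound 4 (0.07 log units; within the scatter) against (1,3-thiazol-2-yl)amino, a 1.1-fold lower number from compound 2 to compound 4 (0.05 log units; within the scatter) against methylamino and a 1.1-fold higher number from compound 1 to compound 4 (0.06 log units; within the scatter) against hydroxy. For the compounds shown here, the tolerance seen among the earlier compounds therefore extends to a six-membered non-aromatic ring with 2 hetero atoms, and the exchange of a group with 1 hydrogen-bond donor for one with 0 hydrogen-bond donors leaves the number within the scatter as well. Nothing available explains why such different groups give numbers this close.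

The compounds shown leave open whether this tolerance would also hold for a carboxylic acid, a long alkyl chain or a plain hydrogen on this aromatic carbon. They also leave open whether the place would behave the same way with the cyano group or the phenyl group exchanged, as all four compounds carry both.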